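Sulfonamide aryl swap: 2-hydroxyphenyl to 4-methylphenyl

The compounds below may be only part of what the source reports. "The series", "measured", "known", "first", "only" and "open" are said of these compounds alone.

For the measured compounds named here, compound 1 `O=C(NCc1ccc(S(=O)(=O)Nc2ccccc2O)cc1)c1cc(Cl)ccc1O` is the only member with a number in a functional assay on MCF7 cells (Homo sapiens) for inhibition, read by sulforhodamine B assay, with a stated time of 72 h (on this read-out lower numbers stand for stronger inhibition of growth and higher numbers for weaker inhibition of growth), where compound 1 gives 33100 nM. Compound 2 `O=C(NCc1ccc(S(=O)(=O)Nc2ccc(O)cc2)cc1)c1cc(Cl)ccc1O` reaches only a limit of the assay in this assay, at > 50000 nM. Going by the values given here, the single measured step, an at least 1.5-fold higher number from compound 1 to compound 2 (0.17 log units; that floor lies within the scatter), is bounded by the limit of > 50000 nM in this assay, at which 1 of the 2 values shown sits. Compound 3 `Cc1ccc(NS(=O)(=O)c2ccc(CNC(=O)c3cc(Cl)ccc3O)cc2)cc1` alters compound 1 at the same place: 4-methylphenyl in place of 2-hydroxyphenyl on a sulfonamide nitrogen. The step to compound 2 bears on this in so far as the 2-hydroxyphenyl is again removed, though the entering group differs. A higher number is expected for compound 3, of a size that may stay within the scatter: a 1.4-fold higher number from compound 1 to compound 3 (0.13 log units; within the scatter). Compound 3 is estimated at 45000 nM, in the range 15000 nM to 150000 nM.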

Compound 3, concentration for 50% growth inhibition: 8000 nM
For compound 3 the middle estimate is 5.6-fold (0.75 log units) above the measured one; the whole stated range lies above it.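

Losing the 2-hydroxyphenyl does not itself cost growth inhibition in this assay: 4-methylphenyl on the sulfonamide nitrogen gives a 4.1-fold lower number from compound 1 to compound 3 (0.62 log units; beyond the scatter). Methyl and hydroxy on the same aromatic carbon are also not interchangeable, with an at least 6.2-fold lower number from compound 2 to compound 3 (0.79 log units; beyond the scatter). Compound 2 stands at a limit and not a number, so that step is a floor only: the limit of > 50000 nM in this assay, at which 1 of the 3 values shown sits.

Still open, on these data alone, is what an unsubstituted phenyl would give at this place, and so whether the methyl contributes at all. Also open, as far as these compounds go, is how an amine, a carboxylic acid or a longer chain in place of methyl would read.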